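The source may report more compounds than this note shows. Statements on the series, on what has been measured and on what is new or still open speak of the compounds shown alone.

- Compound 1 `O=C1c2c[n+]([O-])c3ccccc3c2C(=O)c2c1c1ccccc1n2Cc1cn(C[C@H](O)CO)nn1` gives 8880 nM
- Compound 2 `CC1(C)OC[C@H](Cn2cc(Cn3c4c(c5ccccc53)C(=O)c3c[n+]([O-])c5ccccc5c3C4=O)nn2)O1` gives 100 nM

In a toxicity assay on HEK-293T cells (Homo sapiens) for cytotoxicity, read by MTT assay, with a stated time of 72 h (on this read-out lower numbers stand for stronger inhibition and higher numbers for weaker inhibition), compound 2 holds the lower of the two numbers, at 100 nM. Compound 3 `CC1(C)OC[C@@H](Cn2cc(Cn3c4c(c5ccccc53)C(=O)c3c[n+]([O-])c5ccccc5c3C4=O)nn2)O1` changes only its drawn geometry: the two compounds have the same atoms and bonds and differ only in configuration as drawn: 1 of 1 stereo elements differ; a stereocentre at a saturated ring carbon is drawn S in compound 2 and R in compound 3. Among the compounds with values here, the single measured step, an 89-fold lower number from compound 1 to compound 2 (1.95 log units; beyond the scatter), replaces 1,2-dihydroxyethyl with 2,2-dimethyl-1,3-dioxolan-4-yl, so it is large but concerns a change of group. Within the data shown here, no measured pair tests a stereocentre, so no shift beyond the scatter can be predicted in this assay, in either direction. The expected step is a 1.2-fold higher number from compound 2 to compound 3 (0.08 log units; within the scatter), with real uncertainty. For compound 3 the estimated value is 120 nM, with an expected range from 40 nM to 400 nM.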

Compound 3, half-maximal inhibitory concentration: 6020 nM
Compound 3: middle estimate off by 50-fold (1.70 log units), on the low side; the whole stated range lies below it.
By their numbers in this assay, from the lowest: compound 2; then compounds 3 and 1 (each within the scatter of the next).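

In this assay the stereocentre at the saturated ring carbon proves decisive, with a 60-fold higher number from compound 2 to compound 3 (1.78 log units; beyond the scatter). That step can be put down to configuration alone because of one fact: the fact that compounds 2 and 3 differ only in the configuration as drawn. The gain from 2,2-dimethyl-1,3-dioxolan-4-yl in place of 1,2-dihydroxyethyl therefore appears only with the S form, while the R form gives a 1.5-fold lower number from compound 1 to compound 3 (0.17 log units; within the scatter). As far as these compounds go, whether an amine or a longer chain in place of the dioxolane ring would respond to configuration in the same way remains open. Whether the S form also gives the lower number in other cell types is open too.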